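This account rests on a few compounds, and the source may have more. Where it says the series, first, only, none or still open, it means among the compounds named here.

Working notes on the series. In an ADME assay on L02 cells (Homo sapiens) for inhibition, read by CCK-8 assay, with a stated time of 48 h (on this read-out higher numbers stand for weaker inhibition of growth and lower numbers for stronger inhibition of growth), compound 1 (`Cc1ccccc1Nc1nc(Nc2ccc(N3CCN(C)CC3)cn2)ncc1Cl`) gives 5980 nM and compound 2 (`CN1CCN(c2ccc(Nc3ncc(Cl)c(Nc4ccccc4)n3)nc2)CC1`) gives 7990 nM on the same read-out. Within the data shown here, compound 2 therefore stands within the scatter of compound 1, and these are the only two numbers so far.

Compound 3 (`CN1CCN(c2ccc(Nc3ncc(Cl)c(NCc4ccccc4)n3)nc2)CC1`) differs from compound 2 by benzyl in place of phenyl on a nitrogen on an aromatic ring, that is, anilino to benzylamino: benzyl in place of phenyl on a nitrogen on an aromatic ring in the counted terms.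

Among the measured compounds shown here, the only measured step is a 1.3-fold higher number from compound 1 to compound 2 (0.13 log units; within the scatter) for hydrogen in place of methyl on an aromatic carbon. For the measured compounds named here, that is a different change at a different place, so it bears on this one only loosely, and no measured step covers a change on the nitrogen. On that thin evidence, no step beyond the scatter is expected in this assay and no direction is favoured.

The estimated move is a 1.1-fold lower number from compound 2 to compound 3 (0.06 log units; within the scatter) and it should be read as no real change. For compound 3 the expected value is 7000 nM with an estimated range of 2500 nM to 20000 nM in this read-out.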

Compound 3, concentration for 50% growth inhibition: 20300 nM
Estimate against measurement, compound 3: 2.9-fold (0.46 log units) below; the measured number lies above the stated range.
By their numbers in this assay, from the lowest: compounds 1 and 2 (each within the scatter of the next); then compound 3.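

Among these compounds, on the nitrogen that carries the aromatic group, this assay gives the first change that goes beyond the scatter: a 2.5-fold higher number from compound 2 to compound 3 (0.40 log units; beyond the scatter) for benzyl in place of phenyl, that is, anilino to benzylamino. The comparison with the methylated compound runs the same way, with a 3.4-fold higher number from compound 1 to compound 3 (0.53 log units; beyond the scatter) for benzyl in place of 2-methylphenyl, while the earlier 1.3-fold higher number from compound 1 to compound 2 (0.13 log units; within the scatter) on the aromatic carbon left compounds 1 and 2 together, so among these three compounds only the benzylamino compound stands apart, on the side of weaker inhibition of growth, and by a modest margin. Nothing measured alongside these numbers accounts for the shift at this position.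

As far as these compounds go, whether the number keeps rising with a longer chain on this nitrogen, such as phenethyl, or returns with a saturated ring such as cyclohexyl, remains open. Also open, from the compounds shown here alone, is whether a methyl group on the benzyl ring would leave the number unchanged, as the methyl group on the phenyl ring does within the scatter, or would move it.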